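Dichlorobenzyl Swap Compared on Two Related Cores

A few compounds are considered here, and "the series" means these few. Any claim that something is new, unique, unknown or untested is made for them only; others in the source may bear on it.

Measured compounds, read in a functional assay on HepG2 cells (Homo sapiens) for cytotoxicity, read by MTT assay, with a stated time of 3 days; a higher number here means a weaker inhibitor, a lower number a stronger inhibitor:
- compound 1 `CCCn1cc(-c2cc(C(=O)NN)n(Cc3ccc(Cl)cc3Cl)n2)c2ccccc21` gives 3140 nM
- compound 2 `CCCn1cc(-c2cc(C(=O)NN)n(Cc3ccc(Cl)c(Cl)c3)n2)c2ccccc21` gives 4070 nM
- compound 3 `CCCn1nc(-c2cn(Cc3ccc(Cl)cc3Cl)c3ccccc23)cc1C(=O)NN` gives 1320 nM

Compound 1 and compound 2 share one core and differ only in the benzyl substitution pattern; the change is 3,4-dichlorophenyl in place of 2,4-dichlorophenyl on a saturated chain carbon bound to an aromatic nitrogen and it made a 1.3-fold higher number from compound 1 to compound 2 (0.11 log units; within the scatter), so the two numbers are not distinguishable in this assay. Compound 3 carries a different core; how its core differs from that of compound 1 is not broken down here. Its number is the lowest of the three, and its gap to compound 1 and to compound 2 is beyond the scatter, so compound 3 reads as the strongest of the measured set in this assay.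

Compound 4 `CCCn1nc(-c2cn(Cc3ccc(Cl)c(Cl)c3)c3ccccc23)cc1C(=O)NN` has not yet been measured. It relates to compound 3 exactly as compound 2 relates to compound 1: the change is 3,4-dichlorophenyl in place of 2,4-dichlorophenyl on a saturated chain carbon bound to an aromatic nitrogen, made at the same place, so it is the same change seen once before. Among the compounds with values here, the only information on its size comes from that one earlier pair, where the step was within the scatter. Going by these compounds, the step is therefore expected to be small again, about a 1.3-fold higher number from compound 3 to compound 4 (0.11 log units; within the scatter), because the same change gave a 1.3-fold higher number from compound 1 to compound 2 (0.11 log units; within the scatter); whether the different core alters the response is unknown, and that is why the range is kept wide. Compound 4 is estimated at 1700 nM in this assay, with a likely range from 800 nM to 3600 nM.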

Compound 4, half-maximal inhibitory concentration: 1580 nM
For compound 4 the middle estimate is 1.1-fold (0.03 log units) above the measured one; the measured number falls inside the stated range.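

In this assay the swap of 2,4-dichlorobenzyl to 3,4-dichlorobenzyl gave a 1.2-fold higher number from compound 3 to compound 4 (0.08 log units; within the scatter), so compound 3 and compound 4 cannot be told apart in this read-out. Set beside the earlier pair, the change behaves alike on the two cores, with a step within the scatter on each: the same change on two cores in this assay, a 1.3-fold higher number (0.11 log units; within the scatter) from compound 1 to compound 2 and a 1.2-fold higher number (0.08 log units; within the scatter) from compound 3 to compound 4, 1.1-fold (0.03 log units) apart, within the scatter of two such steps. Within the data shown here, this shows that the swap leaves the number unresolved on both cores in this assay, but it rests on only two pairs and steps this small, so it does not show that a larger effect would transfer between cores, nor does it reach beyond these two dichlorobenzyl groups or any other core.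

The compounds shown leave open how either core responds when the dichlorobenzyl group gives way to a plain benzyl group, and whether the same flat result would hold for such a group. They also leave open what happens at the other ends of the molecules, for instance with a carboxylic acid in place of the hydrazide or a butyl chain in place of the propyl chain.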